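Piperidine for methoxyethylamine on a second core

The compounds below may be only part of what the source reports. "The series", "measured", "known", "first", "only" and "open" are said of these compounds alone.

Measured so far in an assay on isolated protein for inhibition of serine/threonine-protein kinase D2 (Homo sapiens), read by mobility shift assay, tested at 30 uM; on this read-out higher numbers stand for more inhibition at the one concentration tested (going by the name of the read-out) and lower numbers for less inhibition:
compound 1 `Cc1cc2c(c(N)nn2C)c(N2CCCCC2)n1` gives 16%
compound 2 `COCCNc1nc(C)cc2c1c(N)nn2C` gives 4%
compound 3 `COCCNc1nc(C)cc2nn(-c3ccccc3)c(N)c12` gives -1%

Compound 4 `Cc1cc2nn(-c3ccccc3)c(N)c2c(N2CCCCC2)n1` has not yet been measured in this assay. It arises from compound 3 by one change, (piperidin-1-yl in place of (2-methoxyethyl)amino on an aromatic carbon). The same change, (piperidin-1-yl in place of (2-methoxyethyl)amino on an aromatic carbon), also turns compound 2 into compound 1, and there it produced a number 12 percentage points higher from compound 2 to compound 1 (beyond the scatter), a modest rise that lies beyond the usual scatter. Compound 3 and compound 2 share the same change site but differ in their cores; that difference is not broken down here, so those two can only be compared by their values, which sit within the scatter of each other. Because compound 1 and compound 2 showed a number 12 percentage points higher from compound 2 to compound 1 (beyond the scatter), a step of similar size is expected from the same change on the core of compound 3, namely a number 12 percentage points higher from compound 3 to compound 4 (beyond the scatter). Compound 4 is therefore estimated at 11%, with a likely range from 0% to 22%.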

Compound 4, a percentage reported as inhibition, at one concentration (the size of the read-out at that concentration, not a potency): 5%
Estimate against measurement, compound 4: 6 percentage points above; the range from low to high includes it.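

Putting piperidin-1-yl in place of (2-methoxyethyl)amino on the core of compound 3 gives, in this assay, a number 6 percentage points higher from compound 3 to compound 4 (within the scatter), a step that cannot be told apart from repeat variation. Set beside the earlier step, the change shows no measurable difference between the two cores: the same change on two cores in this assay, a number 12 percentage points higher (beyond the scatter) from compound 2 to compound 1 and a number 6 percentage points higher (within the scatter) from compound 3 to compound 4, 6 percentage points apart, within the scatter of two such steps. Among the compounds shown here, this does not prove that the rise carries over, as only the step on the core of compound 1 lies beyond the scatter, and two pairs of compounds are too few to establish a rule.

The compounds shown leave open how other groups on this aromatic carbon, such as morpholin-4-yl or a longer amine chain, would read. They also leave open whether the change would behave the same way on further cores.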